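This account rests on a few compounds, and the source may have more. Where it says the series, first, only, none or still open, it means among the compounds named here.

The compounds in this set share a common core and differ only in the aromatic group attached to one end of the urea. Compound 1 `COc1ccccc1NC(=O)N[C@H]1CC[C@H](Oc2ccc(F)cc2)CC1` carries a 2-methoxyphenyl group. In a functional assay on CRL2813 cells (Homo sapiens) for cytotoxicity, read by sulforhodamine B assay, with a stated time of 5 days (on this read-out lower numbers stand for stronger inhibition and higher numbers for weaker inhibition), compound 1 gives > 20000 nM, which is a limit of the assay rather than a number. Compound 2 `O=C(Nc1cccc(C(F)(F)F)c1)N[C@H]1CC[C@H](Oc2cccc(F)c2)CC1` gives 2400 nM in this assay. Compound 3 `O=C(Nc1ccccc1C(=O)O)N[C@H]1CC[C@@H](Oc2ccc(F)cc2)CC1` gives > 20000 nM, again a limit and not a number. Among the compounds with values here, compound 1 thus sits at the limit of > 20000 nM in this assay, at which 2 of the 3 values shown sit, and the values shown give no measured step between any pair of close neighbours.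

Within the data shown here, compound 4 `CSc1ccccc1NC(=O)N[C@H]1CC[C@H](Oc2ccc(F)cc2)CC1` is the first compound to be measured next. Among the measured compounds shown here, its only difference from compound 1 is methylsulfanyl in place of methoxy on an aromatic carbon. With compound 1 reported only as a limit, nothing in the numbers shown can anchor the size of this change. The step from compound 1 to compound 4 in this assay, a number no higher from compound 1 to compound 4 (the limit leaves the size open), is expected to be no larger than the usual scatter, in either direction. Compound 4 is therefore estimated to give 20000 nM, within the range of 7000 nM to 60000 nM, and most likely to be reported once more as a limit rather than a number.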

Compound 4, half-maximal inhibitory concentration: > 20000 nM
Compound 4 gave a limit, no number; the forecaster's own chance of this, stated with the estimate: 70%; the middle value lies on the limit itself.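

In this assay compound 4 gives > 20000 nM, which is a limit and not a number. Compound 1 is also reported only as a limit, and no step can be read between these two compounds. Whether methylsulfanyl in place of methoxy changes the activity at all stays open, because most values shown share one limit: the limit of > 20000 nM in this assay, at which 3 of the 4 values shown sit.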